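This account rests on a few compounds, and the source may have more. Where it says the series, first, only, none or still open, it means among the compounds named here.

Working notes on the series. Among the measured compounds shown here, compound 1, `COc1ccc(C2=NN(C3=NC(=O)/C(=C4\C(=O)Nc5ccc(Br)cc54)S3)C(c3ccc(OC)cc3)C2)cc1`, and compound 2, `COc1ccc(C2CC(c3ccc4ccccc4c3)=NN2C2=NC(=O)/C(=C3\C(=O)Nc4ccccc43)S2)cc1`, share one core and differ in more than one place, so no single step between them is counted. In a functional assay on cells (Leukemia cell, Homo sapiens) for cytotoxicity, read by sulforhodamine B assay, with a stated time of 48 h (a higher number here means a weaker inhibitor of growth, a lower number a stronger inhibitor of growth), compound 1 gives 62700 nM. In this assay compound 2 gives 59600 nM; this number lies within the scatter of the value of compound 1, so the two compounds are not separated by the data and no order between them can be read.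

Compound 3, `COc1ccc(C2CC(c3ccc4ccccc4c3)=NN2C2=NC(=O)/C(=C3\C(=O)Nc4ccc(Br)cc43)S2)cc1`, follows from compound 2 by a single change: bromo in place of hydrogen on an aromatic carbon. For the measured compounds named here, the only other compound carrying a bromo substituent is compound 1, and its value is not distinguished from that of compound 2 while the two also differ elsewhere, so that pair gives no counted step to lean on. With nothing in the series pointing to a shift in either direction, the change from compound 2 to compound 3 is expected to stay within the scatter. Compound 3 is therefore expected to give 60000 nM, with a range from 25000 nM to 150000 nM. The step this estimate means, a 1.0-fold higher number from compound 2 to compound 3 (0.00 log units; within the scatter), is expected to be none beyond the scatter.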

Compound 3, concentration for total growth inhibition: 3370 nM
Estimate against measurement, compound 3: 18-fold (1.25 log units) above; the measured number lies below the stated range.
By their numbers in this assay, from the lowest: compound 3; then compounds 2 and 1 (each within the scatter of the next).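

In this assay, among the compounds shown here, the step of an 18-fold lower number from compound 2 to compound 3 (1.25 log units; beyond the scatter) shows that this aromatic carbon, meta to a fused ring and para to a fused ring, responds strongly to a single change, with bromo in place of hydrogen giving the first counted step. The step of a 19-fold lower number from compound 1 to compound 3 (1.27 log units; beyond the scatter), with naphthalen-2-yl in place of 4-methoxyphenyl on a carbon with a double bond to nitrogen, shows that the other place also matters when bromo is present, just as the bromo step was read with naphthalen-2-yl present, so each step is known only in the company of the other group. Nothing at hand bears on the reason for the size of either step.

The compounds shown leave open whether chloro, methyl or an amine on the same aromatic carbon would give a step of similar size, or whether bromo is particular in this place. They also leave open how far the naphthalen-2-yl step carries over to a phenyl or naphthalen-1-yl group on the carbon with a double bond to nitrogen.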